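From Allyl to 4-Chlorobenzyl: One Step Estimated

This account rests on a few compounds, and the source may have more. Where it says the series, first, only, none or still open, it means among the compounds named here.

compound 1 `O=C1NC(=O)/C(=C/c2cn(-c3ccccc3)nc2-c2ccccc2)S1`: "not evaluated" (no result reported)
compound 2 `C=CCN1C(=O)S/C(=C\c2cn(-c3ccccc3)nc2-c2ccccc2)C1=O`: 50000 nM

In a functional assay on SH-SY5Y cells (Homo sapiens) for inhibition, with stated times of 48 h and 72 h (a lower number here means a stronger inhibitor, a higher number a weaker inhibitor), compound 2 gives 50000 nM, the only number shown in this assay; compound 1 carries no result there. Compound 3 `O=C1S/C(=C\c2cn(-c3ccccc3)nc2-c2ccccc2)C(=O)N1Cc1ccc(Cl)cc1` differs from compound 2 by 4-chlorophenyl in place of vinyl on a saturated chain carbon bound to an amide-type nitrogen in a ring. Within the data shown here, no measured pair shows this change, so its size is open. The writer expects a modest step toward stronger inhibition, a 2.0-fold lower number from compound 2 to compound 3 (0.30 log units; within the scatter), though a step within the usual scatter is nearly as likely. Compound 3 is therefore estimated at 25000 nM, with a range from 6000 nM to 100000 nM.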

Compound 3, half-maximal inhibitory concentration: 80000 nM
The estimate for compound 3 lay 3.2-fold (0.51 log units) below the measured number; the range from low to high includes it.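

In this assay, the first step read at this position, allyl to 4-chlorobenzyl on the amide-type nitrogen in a ring, gives a 1.6-fold higher number from compound 2 to compound 3 (0.20 log units; within the scatter). Compound 2 and compound 3 therefore cannot be told apart here, even though the entering 4-chlorophenyl brings one six-membered aromatic ring of carbon only in place of vinyl. Nothing available explains this result. Going by these compounds, whether an amine, a carboxylic acid or a longer chain at this place would give a clearly different number stays open. On these data alone, how the amide hydrogen of compound 1 compares also stays open.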